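Dichlorophenyl Urea Analogue Against the Cytotoxicity Limit

The source may report more compounds than this note shows. Statements on the series, on what has been measured and on what is new or still open speak of the compounds shown alone.

Three ureas sharing one core have been measured in an ADME assay on WI-38 cells (Homo sapiens) for cytotoxicity, read by MTT assay, with a stated time of 72 h; on this read-out higher numbers stand for weaker inhibition and lower numbers for stronger inhibition. Among the measured compounds shown here, compound 1 `CN(C)CCn1cnnc1-c1cc(Oc2ccc(NC(=O)Nc3cccc(C(F)(F)F)c3)cc2F)ccn1` gives 11200 nM, the only plain number in the set. Compound 2 `CN(C)CCn1cnnc1-c1cc(Oc2ccc(NC(=O)Nc3ccccc3C(F)(F)F)cc2F)ccn1` reaches only the limit > 50000 nM in this assay. Compound 3 `CN(C)CCn1cnnc1-c1cc(Oc2ccc(NC(=O)Nc3ccc(F)c(F)c3)cc2F)ccn1` likewise stops at the limit > 50000 nM, so compound 3 stands at the top of what this assay reports, together with compound 2 (the limit of > 50000 nM in this assay, at which 2 of the 3 values shown sit), while compound 1 alone sits below it. The move from compound 1 to compound 3 reads an at least 4.4-fold higher number from compound 1 to compound 3 (0.64 log units; beyond the scatter), and from compound 1 to compound 2 an at least 4.4-fold higher number from compound 1 to compound 2 (0.64 log units; beyond the scatter); the step from compound 2 to compound 3 is a step that the two limits leave unreadable from compound 2 to compound 3. Compound 4 `CN(C)CCn1cnnc1-c1cc(Oc2ccc(NC(=O)Nc3ccc(Cl)cc3Cl)cc2F)ccn1` is not yet measured; it differs from compound 3 by 2,4-dichlorophenyl in place of 3,4-difluorophenyl on an amide-type nitrogen. Both halogenated phenyl rings so far that are not the 3-(trifluoromethyl)phenyl of compound 1 sit at the limit, so compound 4 is expected to land near that limit as well, with a step of an at least 1.4-fold lower number from compound 3 to compound 4 (0.15 log units; that floor lies within the scatter) that is estimated to stay within the scatter. The estimate for compound 4 in this assay is 35000 nM, expected between 9000 nM and 120000 nM.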

Compound 4, half-maximal inhibitory concentration: 10400 nM
Beside the measured number, compound 4's estimate is 3.4-fold (0.53 log units) above it; measured number inside the range.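

In this assay, putting 2,4-dichlorophenyl on the amide-type nitrogen gives an at least 4.8-fold lower number from compound 3 to compound 4 (0.68 log units; beyond the scatter) and an at least 4.8-fold lower number from compound 2 to compound 4 (0.68 log units; beyond the scatter), so a halogenated phenyl ring at this place does not always stay at the limit. The new ring also gives a 1.1-fold lower number from compound 1 to compound 4 (0.03 log units; within the scatter), which leaves 2,4-dichlorophenyl and 3-(trifluoromethyl)phenyl unseparated in this read-out. Compound 2 and compound 3 remain limits and not numbers, so how far compound 4 truly lies from either stays unknown: the limit of > 50000 nM in this assay, at which 2 of the 4 values shown sit.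

The compounds shown leave open whether both chlorines are needed for the lower number, which a phenyl ring carrying a single chlorine would address. They also leave open whether a non-halogen group, such as methoxy, on this phenyl ring would give a number or a limit.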